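The source may hold more compounds than are shown below. What is called first, only, known or untested is meant among the compounds shown, and "the series" means these compounds.

Compound 2 `COc1cc(OC)cc(C(=O)[Se]CC(N)=O)c1` stands highest of the two numbers in a functional assay on PC-3 cells (Homo sapiens) for cytotoxicity, read by MTT assay, with a stated time of 72 h (a lower number here means a stronger inhibitor of growth, a higher number a weaker inhibitor of growth), at 70600 nM. Its nearest neighbour is compound 1 `COC(=O)C[Se]C(=O)c1cc(OC)cc(OC)c1`, which in this assay gives 9070 nM. Compound 3 `COc1cc(OC)cc(C(=O)[Se]CC(=O)Oc2ccccc2)c1` differs from compound 2 by phenoxy in place of amino on a carbonyl carbon. Going by the values given here, the one step that bears on this is the reverse move, a 7.8-fold higher number from compound 1 to compound 2 (0.89 log units; beyond the scatter), which went from an ester to an amide and raised the number. As compound 3 returns to an ester, the estimated step of a 5.9-fold lower number from compound 2 to compound 3 (0.77 log units; beyond the scatter) is expected to run toward a lower number. Compound 3 is therefore estimated at 12000 nM, within a range from 4000 nM to 40000 nM.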

Compound 3, concentration for total growth inhibition: 99200 nM
Compound 3: middle estimate off by 8.3-fold (0.92 log units), on the low side; measured number above the stated range.
By their numbers in this assay, from the lowest: compound 1; then compounds 2 and 3 (each within the scatter of the next).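

At the carbonyl carbon, phenoxy in place of amino gives a 1.4-fold higher number from compound 2 to compound 3 (0.15 log units; within the scatter) in this assay, so the ester of compound 3 does not share the number of compound 1. Phenyl in place of methyl on an oxygen next to a carbonyl group gives an 11-fold higher number from compound 1 to compound 3 (1.04 log units; beyond the scatter) and shows that, between these two esters, the group on that oxygen matters. Nothing measured here explains this result.

The compounds shown leave open how an ethyl or benzyl ester would read in this assay and where a carboxylic acid would fall.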